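Ester in place of amide on a naphthyl-pyridine acrylamide

The compounds below may be only part of what the source reports. "The series", "measured", "known", "first", "only" and "open" are said of these compounds alone.

Measured so far:
compound 1, `NC(=O)/C=C/c1ccncc1-c1ccc2ccccc2c1`: 12100 nM
compound 2, `CN1CCN(C(=O)/C=C/c2ccncc2-c2ccc(F)cc2)CC1`: "not determined" (no result reported)

Among the compounds with values here, compound 1 is the only compound with a number in a functional assay on HCT-116 cells (Homo sapiens) for inhibition, read by MTT assay, with a stated time of 72 h (on this read-out lower numbers stand for stronger inhibition of growth and higher numbers for weaker inhibition of growth), where compound 1 gives 12100 nM. Compound 2 carries the same double-bonded carbonyl chain on a different core, and in this assay compound 2 gives "not determined" (no result reported), so no comparison between the two can be drawn. Compound 3, `CCOC(=O)/C=C/c1ccncc1-c1ccc2ccccc2c1`, keeps the core of compound 1 and changes only the carbonyl substituent: ethoxy in place of amino on a carbonyl carbon. Within the data shown here, no measured pair shows this change, so its effect rests on expectation alone. Within this series the change is expected to move growth inhibition only modestly, with a step from compound 1 to compound 3 estimated at a 1.3-fold lower number from compound 1 to compound 3 (0.13 log units; within the scatter), that is, not far beyond the scatter. Compound 3 is therefore estimated at 9000 nM in this assay, with a range from 3000 nM to 30000 nM.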

Compound 3, concentration for 50% growth inhibition: 910 nM
The estimate for compound 3 lay 9.9-fold (1.00 log units) above the measured number; the whole stated range lies above it.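

On the shared core, the group on the carbonyl carbon turns out to weigh heavily in this assay: ethoxy in place of amino gives a 13-fold lower number from compound 1 to compound 3 (1.12 log units; beyond the scatter), a step beyond the scatter. This position, a carbonyl carbon whose other neighbour is the double-bonded chain carbon, is therefore not a neutral site for growth inhibition, and the carbamoyl group is not needed there, since the ethoxycarbonyl of compound 3 carries the lower number. Nothing at hand accounts for the size of this step.

The compounds shown leave open whether the step belongs to ethoxy itself or would also appear with a methoxy group, a longer alkoxy chain or a carboxylic acid at this carbonyl carbon. Going by these compounds, whether the same change would act likewise on the core of compound 2 also stays open.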